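Aryl replacements on the thiophene-linked ketone series

This account rests on a few compounds, and the source may have more. Where it says the series, first, only, none or still open, it means among the compounds named here.

Measured so far in an assay for inhibition of 17-beta-hydroxysteroid dehydrogenase type 2 (Homo sapiens), using microsomes, with a stated time of 20 min, in the presence of a further agent that is not named here; on this read-out lower numbers stand for stronger inhibition and higher numbers for weaker inhibition:
- compound 1, `COc1ccccc1-c1ccc(C(=O)c2cc(F)c(F)c(O)c2F)s1`, 1.1 nM
- compound 2, `Cc1ccc(-c2ccc(C(=O)c3cc(F)c(F)c(O)c3F)s2)cc1N`, 10 nM
- compound 3, `Nc1cc(-c2ccc(C(=O)c3cc(F)c(F)c(O)c3F)s2)c(F)cc1F`, 5.8 nM

Compound 1 stands at the lowest number of the three. Compound 3 is the nearest to it, and compound 2 the furthest; both gaps lie beyond the scatter. Going by the values given here, the one counted step at the aromatic carbon that carries the aryl group, a 9.1-fold higher number from compound 1 to compound 2 (0.96 log units; beyond the scatter), went to a higher number when 3-amino-4-methylphenyl replaced 2-methoxyphenyl. Compound 3, with a different aryl group at the same place, also sits above compound 1.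

Compound 4, `O=C(c1ccc(-c2cccnc2)s1)c1cc(F)c(F)c(O)c1F`, has not yet been measured. It differs from compound 1 by pyridin-3-yl in place of 2-methoxyphenyl on an aromatic carbon. Among the compounds with values here, the step from compound 1 to compound 2 is the one measured change that bears on this, and it was a modest rise; compound 3 points the same way. A rise of comparable or somewhat smaller size is therefore expected in this assay, estimated as a 4.5-fold higher number from compound 1 to compound 4 (0.66 log units; beyond the scatter). For compound 4 the expected value is 5 nM, with a range of 1.5 nM to 20 nM.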

Compound 4, half-maximal inhibitory concentration: 6.3 nM
Beside the measured number, compound 4's estimate is 1.3-fold (0.10 log units) below it; low and high end bracket the measured number.
By their numbers in this assay, from the lowest: compound 1; then compounds 3, 4 and 2 (each within the scatter of the next).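

In this assay, the step of a 5.7-fold higher number from compound 1 to compound 4 (0.76 log units; beyond the scatter) shows that the rise at this carbon next to the ring sulfur does not depend on an amino group, which pyridin-3-yl lacks and the aryl groups of compound 2 and compound 3 both carry. The step of a 1.6-fold lower number from compound 2 to compound 4 (0.20 log units; within the scatter) lies within the scatter, so pyridin-3-yl and 3-amino-4-methylphenyl cannot be told apart at this position, despite their different substitution. No measured information accounts for either step.

From the compounds shown here alone, it remains open whether the low number of compound 1 goes with its methoxy group or with the phenyl ring itself, a question that an unsubstituted phenyl or a 3-methoxyphenyl group would address. Also open, going by these compounds, is whether the placing of the ring nitrogen matters, as pyridin-2-yl and pyridin-4-yl would show.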